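Removing a Methoxy from Compound 2: Expected Cytotoxicity

The compounds below may be only part of what the source reports. "The series", "measured", "known", "first", "only" and "open" are said of these compounds alone.

In an ADME assay on RAW264.7 cells (Mus musculus) for cytotoxicity, read by MTT assay, with a stated time of 24 h, tested at 5 ug/mL (on this read-out lower numbers stand for a stronger effect and higher numbers for a weaker effect at the one concentration tested), compound 1 `COc1ccc(C(=O)/C=C/c2ccc(OC)c(OC)c2)c(O)c1` gives 73.9%; compound 2 `COc1ccc(C(=O)/C=C/c2ccc(OC)c(OC)c2OC)c(O)c1` gives 72.5%.

Compound 2 stands on the same footing as compound 1 in this assay, the gap between them being within the scatter. Compound 3 `COc1ccc(C(=O)/C=C/c2cccc(OC)c2OC)c(O)c1` differs from compound 2 by hydrogen in place of methoxy on an aromatic carbon. Within the data shown here, the one measured step that bears on this change is its reverse, a number 1.4 percentage points lower from compound 1 to compound 2 (within the scatter), a change within the scatter. A step of no size beyond the scatter in this assay is therefore expected, in neither direction. Compound 3 is expected to give 73% (range 62% to 84%), an expected step of a number 0.5 percentage points higher from compound 2 to compound 3 (within the scatter).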

Compound 3, a percentage reported as activity, at one concentration (the size of the read-out at that concentration, not a potency): 69.7%
Estimate against measurement, compound 3: 3.3 percentage points above; the measured number falls inside the stated range.
By their numbers in this assay, from the lowest: compounds 3, 2 and 1 (each within the scatter of the next).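

In this assay, the methoxy para to a large group, a place the earlier step did not touch, gives way to hydrogen with a number 2.8 percentage points lower from compound 2 to compound 3 (within the scatter), so this change shows no step beyond the scatter. Together with the earlier step, this means that neither of the two methoxy changes shown moves the read-out beyond the scatter. No measurement bears on why this is so.

On these data alone, whether an amine, a carboxylic acid or a longer alkoxy chain at this place would give a step beyond the scatter stays open.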